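The source may hold more compounds than are shown below. What is called first, only, known or untested is meant among the compounds shown, and "the series" means these compounds.

Measured in a functional assay on HCT-8 cells (Homo sapiens) for cytotoxicity; a higher number here means that more compound is needed for the effect, a lower number that less compound is needed:

- Compound 1 `COC1=C(C)C(=O)/C(=C(O)/C=C/c2ccc(Br)cc2)C(=O)C1(C)C`: 7.4 ug/mL
- Compound 2 `COC1=C(C)C(=O)/C(=C(O)/C=C/c2cccc(OC)c2)C(=O)C1(C)C`: 2.9 ug/mL
- Compound 3 `COC1=C(C)C(=O)/C(=C(O)/C=C/c2ccc(C)cc2)C(=O)C1(C)C`: 4.1 ug/mL

Compound 3 cannot be separated from either of the others, as the data show a 1.4-fold higher number from compound 2 to compound 3 (0.15 log units; within the scatter) and a 1.8-fold lower number from compound 1 to compound 3 (0.26 log units; within the scatter). Compound 4 `COC1=C(C)C(=O)/C(=C(O)/C=C/c2cc(C)cc(C)c2)C(=O)C1(C)C` differs from compound 3 in one group: 3,5-dimethylphenyl in place of 4-methylphenyl on a double-bonded chain carbon bound to a double-bonded chain carbon. Within the data shown here, no measured step makes this same exchange, so the evidence is indirect. Both steps into compound 3 alter the same aromatic group and stay within the scatter. Only a 2.6-fold lower number from compound 1 to compound 2 (0.41 log units; beyond the scatter) goes beyond it, and modestly. The expected result is a 1.1-fold lower number from compound 3 to compound 4 (0.06 log units; within the scatter), which means no change beyond the scatter. For compound 4 the estimated value is 3.6 ug/mL, with an expected range from 1.6 ug/mL to 8 ug/mL.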

Compound 4, concentration for half-maximal effect: 2.9 ug/mL
Estimate against measurement, compound 4: 1.2-fold (0.09 log units) above, and the stated range covers the measured number.
By their numbers in this assay, from the lowest: compounds 2, 4, 3 and 1 (each within the scatter of the next, the first and the last beyond it).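

In this assay, the exchange for 3,5-dimethylphenyl at this double-bonded chain carbon gives a 1.4-fold lower number from compound 3 to compound 4 (0.15 log units; within the scatter) and no change at the digits printed from compound 2 to compound 4 (within the scatter), so the new group cannot be separated from 4-methylphenyl or 3-methoxyphenyl. Only a 2.6-fold lower number from compound 1 to compound 4 (0.41 log units; beyond the scatter) goes beyond the scatter, and modestly, making 3,5-dimethylphenyl the second group after 3-methoxyphenyl to separate from 4-bromophenyl, while 4-methylphenyl does not. Nothing available explains these steps. The compounds shown leave open whether an amine or a carboxylic acid on this aromatic ring would give a step of a different size.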